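The source may report more compounds than this note shows. Statements on the series, on what has been measured and on what is new or still open speak of the compounds shown alone.

Series notes. Compound 1 `C=CCn1c(SCC(=O)Nc2ccc(C(C)=O)cc2)nnc1-c1ccccc1` is the reference: in a functional assay on the whole organism (strain albino) for inhibition, with Rattus norvegicus as the target, read by paw edema, with stated times of 30 min and 1 h, at a dose of 0.28 mmol/kg by the oral route (a lower number here means less inhibition, a higher number more inhibition at the dose given (going by the name of the read-out)), compound 1 gives 48%. Compound 2 `C=CCn1c(SCC(=O)Nc2ccc(/C(C)=N/O)cc2)nnc1-c1ccccc1` differs from it by a group of 4 heavy atoms (2 carbon, 1 nitrogen, 1 oxygen; no ring) in place of a group of 3 heavy atoms (2 carbon, 1 oxygen; no ring), on an aromatic carbon, and in this assay compound 2 gives 61%, a step of a number 13 percentage points higher from compound 1 to compound 2 (beyond the scatter). Compound 3 `C=CCn1c(SCC(=O)Nc2ccc(C(C)=O)cc2)nnc1-c1ccc(OC)c(OC)c1` differs from compound 1 only in the core, by 3,4-dimethoxyphenyl in place of phenyl on an aromatic carbon; in this assay compound 3 gives 56%, a step of a number 8 percentage points higher from compound 1 to compound 3 (within the scatter), so compound 3 and compound 1 are not separated by this measurement, and compound 3 and compound 2 are not separated either.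

Compound 4 `C=CCn1c(SCC(=O)Nc2ccc(/C(C)=N/O)cc2)nnc1-c1ccc(OC)c(OC)c1` is not yet measured. Among the compounds with values here, it differs from compound 3 by a group of 4 heavy atoms (2 carbon, 1 nitrogen, 1 oxygen; no ring) in place of a group of 3 heavy atoms (2 carbon, 1 oxygen; no ring), on an aromatic carbon, which is the same change as the one from compound 1 to compound 2; the place lines read the same word for word. Compound 4 therefore sits on the core of compound 3 and carries the group that marked compound 2.

Expectation for compound 4 in this assay: a step of about a number 12 percentage points higher from compound 3 to compound 4 (beyond the scatter) is expected, resting on the one measured instance of this change, because a number 13 percentage points higher from compound 1 to compound 2 (beyond the scatter) was modest but beyond the scatter. With a single precedent the range is kept wide. Compound 4 is thus estimated at 68%, between 57% and 80%.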

Compound 4, a percentage reported as inhibition, in the whole organism at one dose (the size of the read-out at that dose, not a potency): 53%
Compound 4: middle estimate off by 15 percentage points, on the high side; the measured number lies below the stated range.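

In this assay the replacement of acetyl does not carry over from the core of compound 1 to the core of compound 3, where the step is a number 3 percentage points lower from compound 3 to compound 4 (within the scatter), and the two instances differ: the same change on two cores in this assay, a number 13 percentage points higher (beyond the scatter) from compound 1 to compound 2 and a number 3 percentage points lower (within the scatter) from compound 3 to compound 4, 16 percentage points apart, beyond the scatter of two such steps

The same four compounds read the other way give a number 8 percentage points lower from compound 2 to compound 4 (within the scatter) for 3,4-dimethoxyphenyl in place of phenyl, so this change also depends on its partner: the same change on two cores in this assay, a number 8 percentage points higher (within the scatter) from compound 1 to compound 3 and a number 8 percentage points lower (within the scatter) from compound 2 to compound 4, 16 percentage points apart, beyond the scatter of two such steps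

Both gaps come from one set of four compounds, so they show that the two changes do not add up here, but they do not show which feature of either group is responsible or how the replacement of acetyl behaves on any further core.

Still open, on these data alone, is whether the dependence persists with other groups on the aromatic ring of the core, such as a chlorophenyl or a single methoxy group. Also open, as far as these compounds go, is what happens with a carboxylic acid or an amine in place of acetyl, or with a longer chain in place of the allyl group.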